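This account rests on a few compounds, and the source may have more. Where it says the series, first, only, none or still open, it means among the compounds named here.

Compound 1, `C=C(Br)C(=O)Nc1ccc(/C=C/C(=O)c2ccccc2)cc1`, gives 4000 nM in an ADME assay on CCRF-CEM cells (Homo sapiens) for antiproliferative activity, with a stated time of 48 h; a higher number here means a weaker inhibitor, a lower number a stronger inhibitor. Compound 2, `C=C(Br)C(=O)Nc1ccc(/C=C/C(=O)c2ccc(OC)cc2)cc1`, gives 1400 nM in this assay. Compound 3, `C=C(Br)C(=O)Nc1ccc(C(=O)/C=C/c2cccc(OC)c2)cc1`, gives 1800 nM in this assay.

All three carry the same bromoacrylamide attached to an aromatic ring, joined through an unsaturated ketone linker to a second aromatic ring. Compound 1 and compound 2 differ in one place only, (methoxy in place of hydrogen on an aromatic carbon), and that single change gave a 2.9-fold lower number from compound 1 to compound 2 (0.46 log units; beyond the scatter). Compound 3 has the linker built the other way round, so the difference between its core and the core of compound 1 is not broken down here; its value sits within the scatter of that of compound 2 and beyond the scatter of that of compound 1.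

Compound 4, `C=C(Br)C(=O)Nc1ccc(C(=O)/C=C/c2ccc(OC)c(OC)c2)cc1`, has not yet been measured. It differs from compound 3 by methoxy in place of hydrogen on an aromatic carbon. Among the compounds with values here, this is the same kind of change as the one from compound 1 to compound 2, but not the same: in compound 2 the entering methoxy sits only para to a large group, while in compound 4 it sits ortho to a methoxy group as well as para to a large group, and the core it is added to is the reversed one.

Because the earlier change gave a 2.9-fold lower number from compound 1 to compound 2 (0.46 log units; beyond the scatter), a step of similar direction is expected from compound 3 to compound 4, estimated as a 2.0-fold lower number from compound 3 to compound 4 (0.30 log units; within the scatter). The estimate for compound 4 in this assay is therefore 900 nM, expected to lie between 300 nM and 2700 nM.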

Compound 4, half-maximal inhibitory concentration: 1600 nM
The estimate for compound 4 lay 1.8-fold (0.25 log units) below the measured number; measured number inside the range.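

Methoxy in place of hydrogen on an aromatic carbon gives a 1.1-fold lower number from compound 3 to compound 4 (0.05 log units; within the scatter) in this assay, so on this core the step is too small to count as a real change. Within the data shown here, at first sight this looks unlike the earlier step on the core of compound 1, yet the gap between the two steps is no larger than repeated measurements could produce: the same change on two cores in this assay, a 2.9-fold lower number (0.46 log units; beyond the scatter) from compound 1 to compound 2 and a 1.1-fold lower number (0.05 log units; within the scatter) from compound 3 to compound 4, 2.5-fold (0.40 log units) apart, within the scatter of two such steps The pair of steps therefore does not show that the change acts differently on the two cores, but it does not show that it carries over unchanged either, since there are only two examples, one beyond the scatter and one within it, and the entering methoxy sits ortho to a methoxy group only in compound 4.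

On these data alone, whether a different group at the same place, such as an amine, a carboxylic acid or a longer chain, would shift the number on either core remains open. Also open, as far as these compounds go, is whether the methoxy step on the core of compound 1 would shrink if a methoxy group already stood ortho to the entering one, which would separate the effect of the core from that of the neighbouring group.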